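Methoxy in Place of Methyl on the Aromatic Ring

The source may report more compounds than this note shows. Statements on the series, on what has been measured and on what is new or still open speak of the compounds shown alone.

Of the compounds shown here, three that share one core have been measured in an assay on forebrain for inhibition of Monoamine oxidase (Mus musculus); on this read-out higher numbers stand for an effect only at larger amounts of compound and lower numbers for an effect already at smaller amounts. Compound 1 `C=C=C(CN)Cc1ccccc1` gives 12 umol/kg. Compound 2 `C=C=C(CN)Cc1ccc(Cl)cc1` gives 7 umol/kg, and compound 3 `C=C=C(CN)Cc1ccc(C)cc1` gives 23 umol/kg, the largest of the three numbers, though its difference from compound 1 lies within the scatter, while a 3.3-fold higher number from compound 2 to compound 3 (0.52 log units; beyond the scatter). Compound 4 `C=C=C(CN)Cc1ccc(OC)cc1` differs from compound 3 by methoxy in place of methyl on an aromatic carbon. Among the measured compounds shown here, no measured step involves a methoxy group; the steps that concern a change on this aromatic carbon are a 1.7-fold lower number from compound 1 to compound 2 (0.23 log units; within the scatter), a 1.9-fold higher number from compound 1 to compound 3 (0.28 log units; within the scatter) and a 3.3-fold higher number from compound 2 to compound 3 (0.52 log units; beyond the scatter), all small. A step of no more than similar size, with no clear direction, is therefore expected in this assay, namely a 1.2-fold lower number from compound 3 to compound 4 (0.06 log units; within the scatter). Compound 4 is estimated at 20 umol/kg, between 8 umol/kg and 50 umol/kg.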

Compound 4, dose for half-maximal effect: 16 umol/kg
For compound 4 the middle estimate is 1.3-fold (0.10 log units) above the measured one; the measured number falls inside the stated range.
By their numbers in this assay, from the lowest: compounds 2, 1, 4 and 3 (each within the scatter of the next, the first and the last beyond it).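

In this assay, methoxy, which brings a hydrogen-bond acceptor to this aromatic carbon, cannot be told apart from methyl or from hydrogen, with a 1.4-fold lower number from compound 3 to compound 4 (0.16 log units; within the scatter) and a 1.3-fold higher number from compound 1 to compound 4 (0.12 log units; within the scatter). Only chloro separates from it, with a 2.3-fold higher number from compound 2 to compound 4 (0.36 log units; beyond the scatter), so compound 2 is set apart from compound 3 and compound 4 alike. Nothing at hand explains this difference. As far as these compounds go, what an amine, a carboxylic acid or a longer chain such as ethoxy would give on this aromatic carbon stays open.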